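The compounds below may be only part of what the source reports. "The series", "measured", "known", "first", "only" and "open" are said of these compounds alone.

Compound 1 `CC(C)(C)Cc1ccc2nc(N)sc2c1` gives in a functional assay on the whole organism with Rattus norvegicus as the target (on this read-out lower numbers stand for an effect already at smaller amounts and higher numbers for an effect only at larger amounts of compound), only a limit, > 10 mg/kg, and not a number.
Compound 2 `Nc1nc2ccc(SC(F)(F)F)cc2s1` gives in this assay a value of 8 mg/kg.
Compound 3 `CCCn1c(=N)sc2cc(OC(F)(F)F)ccc21` gives in this assay a value of 4.5 mg/kg.

Of the two numbers shown, compound 3 has the lowest, but its nearest neighbour, compound 2, lies within the usual scatter of it, so the two cannot be told apart on this read-out. Compound 1 adds only (the limit of > 10 mg/kg in this assay, at which 1 of the 3 values shown sits), which sets no number to compare against.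

Compound 4 `CNS(=O)(=O)CCn1c(=N)sc2cc(OC(F)(F)F)ccc21` differs from compound 3 in one place: methylsulfamoyl in place of methyl on a saturated chain carbon, two bonds along the chain from an aromatic nitrogen. Among the compounds with values here, the only measured step, an at least 1.2-fold lower number from compound 1 to compound 2 (0.09 log units; that floor lies within the scatter), exchanges groups on an aromatic carbon, a different part of the shared core, and its size lies within the scatter; it says nothing about a change on the saturated chain. Within the data shown here, no measured pair of compounds shares the chain change, so there is no step to lean on. No step beyond the scatter is therefore expected in either direction in this assay, and the uncertainty is correspondingly wide. Compound 4 is estimated at 5 mg/kg, with a range from 2 mg/kg to 15 mg/kg, which corresponds to an expected 1.1-fold higher number from compound 3 to compound 4 (0.05 log units; within the scatter).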

Compound 4, dose for half-maximal effect: 4 mg/kg
For compound 4 the middle estimate is 1.3-fold (0.10 log units) above the measured one; the measured number falls inside the stated range.
By their numbers in this assay, from the lowest: compounds 4, 3 and 2 (each within the scatter of the next). At a limit, above all of these: compound 1.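

The saturated chain carbon, two bonds along the chain from an aromatic nitrogen, accepts a far larger group with no visible cost in this assay: putting methylsulfamoyl, with 5 heavy atoms, 1 hydrogen-bond donor and 2 hydrogen-bond acceptors, in place of methyl gives a 1.1-fold lower number from compound 3 to compound 4 (0.05 log units; within the scatter), so the two compounds cannot be told apart on this read-out. Within the data shown here, the only earlier step concerned a group on an aromatic carbon, so this is the first measured information about the chain, and it shows that a change of this size here can leave the dose for the effect where it was. Nothing measured here explains why the exchange is tolerated.

Going by these compounds, one exchange cannot describe the whole position, so it remains open whether an amine, a carboxylic acid or a longer chain at this carbon would also leave the number in place or would move it beyond the scatter. On these data alone, it is equally open whether methylsulfamoyl would behave the same way with (trifluoromethyl)sulfanyl, the group of compound 2, on the aromatic carbon of the shared core.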